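Compound 2 to compound 3: one added acetoxy

The compounds below may be only part of what the source reports. "The series", "measured", "known", "first", "only" and "open" are said of these compounds alone.

Measured in a functional assay on P388 cells (Mus musculus) for cytotoxicity, read by MTT assay, with a stated time of 72 h (on this read-out higher numbers stand for an effect only at larger amounts of compound and lower numbers for an effect already at smaller amounts), both values being limits:
- compound 1 `C=C1[C@@]23CC(=O)O[C@@H](c4ccoc4)[C@]2(C)C[C@@H](O)[C@]1(O)[C@@]1(C)[C@@H](O3)[C@@H](OC(C)=O)[C@@H](OC(C)=O)C(C)(C)[C@@H]1CC(=O)OC`: > 5 ug/mL
- compound 2 `C=C1[C@@H]2[C@H](OC(C)=O)C[C@@]3(C)[C@H](c4ccoc4)OC(=O)C[C@]13O[C@H]1C[C@@H](OC(C)=O)C(C)(C)[C@H](CC(=O)OC)[C@]12C`: > 5 ug/mL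

In this assay compound 2 gives > 5 ug/mL, which is a limit and not a number. Among the compounds with values here, no measured compound has left it so far: the limit of > 5 ug/mL in this assay, at which 2 of the 2 values shown sit.

Compound 3 `C=C1[C@@H]2[C@H](OC(C)=O)C[C@@]3(C)[C@H](c4ccoc4)OC(=O)C[C@]13O[C@H]1[C@@H](OC(C)=O)[C@@H](OC(C)=O)C(C)(C)[C@H](CC(=O)OC)[C@@]21C` differs from compound 2 by acetoxy in place of hydrogen on a saturated ring carbon. Within the data shown here, no measured step covers this change. The step that the limit leaves unreadable from compound 2 to compound 3 in this assay is expected to be none beyond the scatter. For compound 3 the estimate is 7 ug/mL, with an expected range of 3 ug/mL to 20 ug/mL.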

Compound 3, concentration for half-maximal effect: > 5 ug/mL
Compound 3: only a limit was reported (the forecaster's own chance of this, stated with the estimate: 75%); the middle value is on the limit's open side.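

No step from compound 2 to compound 3 can be read in this assay, as both results are limits and not numbers: the limit of > 5 ug/mL in this assay, at which 3 of the 3 values shown sit.

Left open is whether acetoxy in place of hydrogen on that saturated ring carbon shifts the read-out at all, and at what concentration any of these compounds acts.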